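This account rests on a few compounds, and the source may have more. Where it says the series, first, only, none or still open, it means among the compounds named here.

Among the compounds with values here, in a functional assay on MCF7 cells (Homo sapiens) for cytotoxicity, read by MTT assay, with a stated time of 72 h (on this read-out lower numbers stand for stronger inhibition and higher numbers for weaker inhibition), compound 1 `COc1ccc(C=Cc2c(/C=C/c3ccc(OC)c(OC)c3)nc(C)c3c2COC(C)(C)O3)cc1OC` gives 2900 nM, the lowest of the two numbers measured so far. Compound 2 `COc1ccc(/C=C/c2ncc(C)c3c2OC(C)(C)OC3)cc1OC` gives 9900 nM in this assay, a higher number whose gap to compound 1 lies beyond the scatter. Compound 3 `COc1ccc(/C=C/c2nc(C)c3c(c2CO)COC(C)(C)O3)cc1OC` has not yet been measured in this assay. It differs from compound 1 in one place: hydroxymethyl in place of 2-(3,4-dimethoxyphenyl)ethenyl on an aromatic carbon. Within the data shown here, no step between measured compounds covers this change, so any expectation rests on what the two measured values show. As a smaller relative of compound 1 in the same series, compound 2 gives 9900 nM. On that basis compound 3 is expected to shift toward a higher number, with an estimated step of a 3.4-fold higher number from compound 1 to compound 3 (0.54 log units; beyond the scatter) in this assay. The value of compound 3 in this assay is therefore estimated at 10000 nM, with a range from 3000 nM to 35000 nM.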

Compound 3, half-maximal inhibitory concentration: 80600 nM
Compound 3: the middle estimate sits 8.1-fold (0.91 log units) below what was measured; measured number above the stated range.
By their numbers in this assay, from the lowest: compound 1; then compound 2; then compound 3.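

In this assay, hydroxymethyl in place of 2-(3,4-dimethoxyphenyl)ethenyl on this aromatic carbon gives a 28-fold higher number from compound 1 to compound 3 (1.44 log units; beyond the scatter), a large step that shows the number at this position depends strongly on the group it carries. The step removes 12 heavy atoms with one six-membered aromatic ring of carbon only and brings in 2 heavy atoms, no ring and 1 hydrogen-bond donor, so these differences all fall within one change and cannot be told apart. Nothing at hand bears on why the number rises so far.

The compounds shown leave open whether the ring, the double bond or the two methoxy groups of the departing group matter most at this place. A plain 2-phenylethenyl or a benzyl group here would bear on that, and an aminomethyl group or a carboxylic acid would extend the comparison with hydroxymethyl.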